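Spiro Piperidine Series: Clearance Outlook for a Pyrrole Analogue

A few compounds are considered here, and "the series" means these few. Any claim that something is new, unique, unknown or untested is made for them only; others in the source may bear on it.

The shared core appears in compound 1 `c1cc2c(s1)CCOC21CCNCC1`, which in an ADME assay on microsomes from liver (Homo sapiens) for metabolic stability, read by LC-MS, using NADPH, with a stated time of 30 min, tested at 0.5 uM (a lower number here means slower removal, a higher number faster removal of the compound), gives "not determined" (no result reported). Compound 2 `Cc1ccc(CN2CCC3(CC2)OCCc2sccc23)cc1` gives in this assay 22.5 mL/min/g. Compound 3 `Cc1ccccc1CN1CCC2(CC1)OCCc1sccc12` stands without a number: in this assay it gives "not determined" (no result reported), so its place in the series rests on no figure of its own. Compound 4 `Cc1ccc(CN2CCC3(CC2)OCCc2sccc23)[nH]1` differs from compound 3 by 5-methyl-1H-pyrrol-2-yl in place of 2-methylphenyl on a saturated chain carbon bound to an amine nitrogen in a ring. For the measured compounds named here, no measured pair shows this change, so the data offer no step to lean on; the only anchor is the result of compound 2 in this assay. For compound 4 a value near that anchor is estimated, 18 mL/min/g, with a range from 7 mL/min/g to 45 mL/min/g, since the data give no ground to expect a shift beyond the scatter.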

Compound 4, intrinsic clearance in a liver preparation (reported as CLH), per the amount of preparation that the assay uses: 4.1 mL/min/g
Compound 4: middle estimate off by 4.4-fold (0.64 log units), on the high side, outside the stated range (below it).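

The swap of 4-methylphenyl for 5-methyl-1H-pyrrol-2-yl on a saturated chain carbon bound to an amine nitrogen in a ring gives, in this assay, a 5.5-fold lower number from compound 2 to compound 4 (0.74 log units; beyond the scatter). For the compounds shown here, this is the first step the series offers, and it shows that the aromatic ring at this place can move the read-out beyond the scatter. No measurement at hand accounts for the change. On these data alone, whether a furan ring or a pyridine ring at this place would give a similar number stays open, as does the standing of compound 3, which has no figure of its own.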